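The source may hold more compounds than are shown below. What is called first, only, known or untested is meant among the compounds shown, and "the series" means these compounds.

Measured so far:
compound 1, `CCC1C(=O)N(C)c2cnc(-n3ccc4cc(C(N)=O)ccc43)nc2N1c1ccn(C)n1`: 31300 nM
compound 2, `CC[C@@H]1C(=O)N(C)c2cnc(Nc3ccc(S(=O)(=O)NCCO)cc3)nc2N1C1CCCC1`: 546 nM
compound 3, `CCC1C(=O)N(C)c2cnc(Nc3ccc(S(=O)(=O)NCCCO)cc3)nc2N1c1ccn(C)n1`: 13400 nM

All three numbers come from a functional assay on K562 cells (Homo sapiens) for antiproliferative activity, read by CCK-8 assay, with a stated time of 72 h; on this read-out lower numbers stand for stronger inhibition of growth and higher numbers for weaker inhibition of growth. Compound 3 holds the second highest of the three in this assay; its nearest neighbour is compound 1 and the furthest is compound 2, both gaps beyond the scatter.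

Compound 4, `CCC1C(=O)N(C)c2cnc(Nc3ccc(S(=O)(=O)NCC(C)C)cc3)nc2N1c1ccn(C)n1`, is not yet measured. It differs from compound 3 by isopropyl in place of 2-hydroxyethyl on a saturated chain carbon bound to a sulfonamide nitrogen. Going by the values given here, no step between measured compounds covers this change, so the expectation rests on compound 3 alone.

The step from compound 3 to compound 4 is expected to be small, of the order of the scatter, as a 1.1-fold lower number from compound 3 to compound 4 (0.05 log units; within the scatter). For compound 4 the value in this assay is estimated at 12000 nM, within 4000 nM to 40000 nM.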

Compound 4, concentration for 50% growth inhibition: 7300 nM
Beside the measured number, compound 4's estimate is 1.6-fold (0.22 log units) above it, and the stated range covers the measured number.
By their numbers in this assay, from the lowest: compound 2; then compounds 4 and 3 (each within the scatter of the next); then compound 1.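

In this assay isopropyl in place of 2-hydroxyethyl on a saturated chain carbon bound to a sulfonamide nitrogen gives a 1.8-fold lower number from compound 3 to compound 4 (0.26 log units; within the scatter) and so stays within the scatter. At this place, in this pair, the 3-hydroxypropyl and isobutyl chains on the sulfonamide cannot be told apart, even though the hydrogen-bond donor and acceptor of the leaving group are gone. No supporting measurement bears on this result.

From the compounds shown here alone, whether an amine, a carboxylic acid or a longer chain at this place would move the number beyond the scatter remains open. Also open, going by these compounds, is whether this step would read the same on the core of compound 2.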